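The source may report more compounds than this note shows. Statements on the series, on what has been measured and on what is new or still open speak of the compounds shown alone.

Measured so far in a functional assay on the whole organism (strain Wistar) for inhibition, with Rattus norvegicus as the target, read by paw edema, with a stated time of 3 h, at a dose of 100 mg/kg; on this read-out lower numbers stand for less inhibition and higher numbers for more inhibition at the one dose given (going by the name of the read-out):
compound 1 `COc1cc2c(cc1OC)C(CC(=O)Nc1cccc(Cl)c1)CC2` gives 24.6%
compound 2 `COc1cc2c(cc1OC)C(CC(=O)Nc1ccc(Cl)cc1)CC2` gives 60.9%

For the measured compounds named here, compound 1 stands at the lower of the two numbers in this assay; its only neighbour is compound 2, and the single step between measured compounds, a number 36.3 percentage points higher from compound 1 to compound 2 (beyond the scatter), is beyond the scatter and large. That step is 4-chlorophenyl in place of 3-chlorophenyl on an amide-type nitrogen, a rearrangement within the same kind of ring.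

Compound 3 `COc1cc2c(cc1OC)C(CC(=O)Nc1cccnc1)CC2` is not yet measured. It differs from compound 1 as follows: pyridin-3-yl in place of 3-chlorophenyl on an amide-type nitrogen. Going by the values given here, no measured step covers this kind of change; the one step available swaps one chlorophenyl for another and gives no reading on the exchange of a carbon ring for one with a hetero atom. The expectation for compound 3 in this assay therefore rests on the value of compound 1 alone, with a wide range, and the expected step of a number 5.4 percentage points higher from compound 1 to compound 3 (within the scatter) is centred on no change beyond the scatter. Compound 3 is estimated at 30% in this assay, with a range from 8% to 55%.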

Compound 3, a percentage reported as inhibition, in the whole organism at one dose (the size of the read-out at that dose, not a potency): 33.3%
Beside the measured number, compound 3's estimate is 3.3 percentage points below it, and the stated range covers the measured number.
By their numbers in this assay, from the lowest: compounds 1 and 3 (each within the scatter of the next); then compound 2.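

In this assay, pyridin-3-yl in place of 3-chlorophenyl on an amide-type nitrogen gives a number 8.7 percentage points higher from compound 1 to compound 3 (within the scatter) and so leaves the read-out within the scatter, even though the entering ring carries a hetero atom and a hydrogen-bond acceptor and the chlorine is gone. Set against 4-chlorophenyl, the same ring gives a number 27.6 percentage points lower from compound 2 to compound 3 (beyond the scatter) and thus adds a second comparison in which compound 2 stands apart; among these three groups on the nitrogen, only 4-chlorophenyl gives a number beyond the scatter of the others. No measurement at hand accounts for this gap or for the lack of a clear step between compound 1 and compound 3.

As far as these compounds go, it remains open whether the higher number of compound 2 is tied to chlorine itself, which 4-fluorophenyl or 4-methoxyphenyl on the same nitrogen would address, or also appears with a hetero atom in the ring, as in pyridin-4-yl. Also open, from the compounds shown here alone, is how the series responds to changes away from this ring, such as a longer chain between the carbonyl and the core, or a carboxylic acid in place of the amide.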